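The source may report more compounds than this note shows. Statements on the series, on what has been measured and on what is new or still open speak of the compounds shown alone.

Measured compounds:
compound 1, `CC(C)(C)c1ccc(CNCCCNS(=O)(=O)c2cc(C(F)(F)F)cc(C(F)(F)F)c2)cc1`, 2700 nM
compound 2, `O=S(=O)(NCCNCc1ccc(-c2ccccc2)cc1)c1cc(C(F)(F)F)cc(C(F)(F)F)c1`, 2800 nM
compound 3, `O=S(=O)(NCCCNCC1COc2ccccc2O1)c1cc(C(F)(F)F)cc(C(F)(F)F)c1`, 2900 nM

Each of these three compounds was tested in a functional assay on ASPC1 cells (Homo sapiens) for inhibition, read by MTT assay, with a stated time of 72 h; on this read-out lower numbers stand for stronger inhibition of growth and higher numbers for weaker inhibition of growth. They share a common core that ends in a saturated chain carbon bound to an amine nitrogen, and they differ in the group attached there. Compound 3 carries the highest of the three numbers, yet its gap to compound 2 and its gap to compound 1 both lie within the scatter, so the three compounds cannot be told apart on this read-out.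

Compound 4, `O=S(=O)(NCCCNCc1cccc2ccccc12)c1cc(C(F)(F)F)cc(C(F)(F)F)c1`, is the next compound. It differs from compound 3 in one place: naphthalen-1-yl in place of 2,3-dihydro-1,4-benzodioxin-2-yl on a saturated chain carbon bound to an amine nitrogen. Going by the values given here, only one measured step changes that same place, a 1.1-fold higher number from compound 1 to compound 3 (0.03 log units; within the scatter), and it lay within the scatter. Compound 2, with yet another group there, gives a value close to that of compound 3. Among the compounds with values here, nothing so far shows that swapping one group for another at this place moves the number beyond the scatter, so the step of a 1.0-fold lower number from compound 3 to compound 4 (0.02 log units; within the scatter) is expected to be small. Compound 4 is therefore expected to give about 2800 nM in this assay, with a range from 1400 nM to 5600 nM.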

Compound 4, concentration for 50% growth inhibition: 21000 nM
For compound 4 the middle estimate is 7.5-fold (0.88 log units) below the measured one, outside the stated range (above it).
By their numbers in this assay, from the lowest: compounds 1, 2 and 3 (each within the scatter of the next); then compound 4.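

In this assay the group at this place, on a saturated chain carbon bound to an amine nitrogen, now clearly matters: naphthalen-1-yl in place of 2,3-dihydro-1,4-benzodioxin-2-yl gives a 7.2-fold higher number from compound 3 to compound 4 (0.86 log units; beyond the scatter) and naphthalen-1-yl in place of 4-(tert-butyl)phenyl gives a 7.8-fold higher number from compound 1 to compound 4 (0.89 log units; beyond the scatter) and both steps lie beyond the scatter, whereas the step between the two groups it replaces, a 1.1-fold higher number from compound 1 to compound 3 (0.03 log units; within the scatter) stayed within it. The change from compound 3 to compound 4 keeps the count of 10 heavy atoms, so that count alone does not separate the two groups, and the loss of the two oxygen atoms does not account for the shift on its own, since the 4-(tert-butyl)phenyl of compound 1 has no oxygen either and still sits with compound 3. Nothing shown here gives a measured reason for this weaker inhibition of growth.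

From the compounds shown here alone, it remains open whether the loss belongs to naphthalen-1-yl specifically or to fused aromatic rings in general. A naphthalen-2-yl group, a quinolin-4-yl group or a plain phenyl group at this place would help to separate these possibilities.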